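Notes: 3-bromophenyl to 4-hydroxyphenyl in the series

The compounds below may be only part of what the source reports. "The series", "measured", "known", "first", "only" and "open" are said of these compounds alone.

Measured in a functional assay on OVCAR-5 cells (Homo sapiens) for inhibition, read by CCK-8 assay, with a stated time of 72 h, tested at 10 uM; a higher number here means more inhibition of growth at the concentration tested, a lower number less inhibition of growth:
- compound 1 `CN(C)C(=O)c1cc2cnc(Nc3ccc(NC(=O)C4(C(=O)Nc5cccc(F)c5)CC4)cc3)nc2n1C1CCCC1`: 85.6%
- compound 2 `CN(C)C(=O)c1cc2cnc(Nc3ccc(NC(=O)C4(C(=O)Nc5ccccc5F)CC4)cc3)nc2n1C1CCCC1`: 82.6%
- compound 3 `CN(C)C(=O)c1cc2cnc(Nc3ccc(NC(=O)C4(C(=O)Nc5cccc(Br)c5)CC4)cc3)nc2n1C1CCCC1`: 89.6%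

Compound 3 does not separate from the other two compounds, as a number 4 percentage points higher from compound 1 to compound 3 (within the scatter) and a number 7 percentage points higher from compound 2 to compound 3 (within the scatter) both stay within the scatter. The next structure, compound 4 `CN(C)C(=O)c1cc2cnc(Nc3ccc(NC(=O)C4(C(=O)Nc5ccc(O)cc5)CC4)cc3)nc2n1C1CCCC1`, has 4-hydroxyphenyl in place of 3-bromophenyl on an amide-type nitrogen.

Two further measured steps bear on this change only in part. Moving the fluoro group gave a number 3 percentage points lower from compound 1 to compound 2 (within the scatter), and bromo in place of fluoro gave a number 4 percentage points higher from compound 1 to compound 3 (within the scatter). Among the measured compounds shown here, both are small, but neither introduces a hydroxy group, so the series offers no direct precedent. Some loss is expected, with an uncertain size, and the estimate is a number 11.6 percentage points lower from compound 3 to compound 4 (beyond the scatter). For compound 4 the expected value is 78%, with an estimated range of 58% to 91%.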

Compound 4, percent growth inhibition at one concentration: 90.9%
Compound 4: middle estimate off by 12.9 percentage points, on the low side, and the stated range covers the measured number.
By their numbers in this assay, from the lowest: compounds 2, 1, 3 and 4 (each within the scatter of the next).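

In this assay, the amide-type nitrogen takes 4-hydroxyphenyl in place of each halogenated phenyl without any separation from those compounds (a number 1.3 percentage points higher from compound 3 to compound 4 (within the scatter); a number 8.3 percentage points higher from compound 2 to compound 4 (within the scatter); a number 5.3 percentage points higher from compound 1 to compound 4 (within the scatter)). Across these four compounds, a halogen on this ring is therefore not required for a reading at this level, and the hydrogen-bond donor and acceptor that enter with 4-hydroxyphenyl, absent from 3-bromophenyl, bring no step beyond the scatter. No evidence is available to explain why this change leaves the reading within the scatter.

On these data alone, all four readings come from one concentration, so any differences that might appear at lower concentrations remain open. Also open is whether an amine or a carboxylic acid on this phenyl ring, or a longer chain in place of the ring, would stay within the scatter of these compounds in this assay.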